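The source may hold more compounds than are shown below. What is called first, only, known or untested is meant among the compounds shown, and "the series" means these compounds.

Of the compounds shown here, three built on one shared core have been measured. Compound 1 `CC1=CC[C@@H]([C@@](C)(O)CCCC(C)(C)NC=S)CC1` carries a short thiourea terminus; in a functional assay on HT-29 cells (Homo sapiens) for cytotoxicity, read by sulforhodamine B assay (on this read-out lower numbers stand for stronger inhibition of growth and higher numbers for weaker inhibition of growth), compound 1 gives 47900 nM. Compound 2 `COc1ccc(/C=N\NC(=S)NC(C)(C)CCC[C@](C)(O)[C@@H]2CC=C(C)CC2)cc1` extends that terminus into a hydrazone bearing a 4-methoxyphenyl group, and in this assay compound 2 gives 35200 nM. Compound 3 `CC1=CC[C@@H]([C@@](C)(O)CCCC(C)(C)NC(=S)N/N=C\c2ccc(O)cc2)CC1` differs from compound 2 only by hydrogen in place of methyl on an oxygen on an aromatic ring; in this assay compound 3 gives 31500 nM. Compound 2 therefore holds the second highest of the three numbers, with its gap to compound 3 and its gap to compound 1 both within the scatter. The step of a 1.1-fold lower number from compound 2 to compound 3 (0.05 log units; within the scatter) shows that altering the substituent on that aromatic ring left the number essentially in place. Compound 4 `CC1=CC[C@@H]([C@@](C)(O)CCCC(C)(C)NC(=S)N/N=C\c2ccccc2[N+](=O)[O-])CC1` makes a larger change at the same site: 2-nitrophenyl in place of 4-methoxyphenyl on a carbon with a double bond to nitrogen. Within the data shown here, only the step from compound 2 to compound 3 bears directly on this change, and it was within the scatter. Compound 4 is consequently expected to show no step beyond the scatter, a 1.0-fold lower number from compound 2 to compound 4 (0.00 log units; within the scatter). The estimate for compound 4 in this assay is 35000 nM, within a range from 15000 nM to 80000 nM.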

Compound 4, concentration for total growth inhibition: 16800 nM
Estimate against measurement, compound 4: 2.1-fold (0.32 log units) above, and the stated range covers the measured number.
By their numbers in this assay, from the lowest: compounds 4, 3, 2 and 1 (each within the scatter of the next, the first and the last beyond it).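

In this assay, the group on the carbon with a double bond to nitrogen now produces a step beyond the scatter, which the swap between the two oxygen-bearing aryl groups had not done. Placing 2-nitrophenyl there in place of 4-methoxyphenyl gives a 2.1-fold lower number from compound 2 to compound 4 (0.32 log units; beyond the scatter), a modest step. The same group in place of 4-hydroxyphenyl gives a 1.9-fold lower number from compound 3 to compound 4 (0.27 log units; within the scatter), so this position responds to the change against only one of the two partners, and by a small margin.

From the compounds shown here alone, it remains open whether the nitro group itself or its place on the ring accounts for the step. A plain phenyl, or an amine or a carboxylic acid on that ring, could help to settle this. No evidence is available here that explains the step.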